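Iodo in Place of tert-Butyl: Estimating Compound 4

A few compounds are considered here, and "the series" means these few. Any claim that something is new, unique, unknown or untested is made for them only; others in the source may bear on it.

Compound 1, `C[C@@H](NC(=O)Nc1ccccc1C(C)(C)C)c1ccccc1`: 95%
Compound 2, `C[C@H](NC(=O)Nc1ccccc1C(C)(C)C)c1ccccc1`: 99%
Compound 3, `C[C@@H](NC(=O)Nc1ccc(C(F)(F)F)cc1)c1ccccc1`: 89%

All three values come from an ADME assay on the whole organism with Oryza sativa as the target, tested at 1 uM (a lower number here means a stronger effect, a higher number a weaker effect of the compound at the concentration tested), and lie within the usual scatter of one another, so none can be called stronger or weaker. The nearest to compound 1 is compound 2, with a number 4 percentage points higher from compound 1 to compound 2 (within the scatter); these two share every atom and bond and differ only in configuration, as the fact that compounds 1 and 2 differ only in the configuration as drawn shows. Compound 3 also sits within the scatter of compound 1.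

Compound 4, `C[C@@H](NC(=O)Nc1ccccc1I)c1ccccc1`, differs from compound 1 by iodo in place of tert-butyl on an aromatic carbon. Going by the values given here, the single measured step, a change of configuration only, does not touch a group on the ring, so no measured step bears on this change. With nothing to point either way, the expected step of a number 5 percentage points lower from compound 1 to compound 4 (within the scatter) is none beyond the scatter, and compound 4 is estimated at 90%, within 65% to 100%.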

Compound 4, a percentage reported as activity, at one concentration (the size of the read-out at that concentration, not a potency): 100%
Compound 4: the middle estimate sits 10 percentage points below what was measured; the measured number falls inside the stated range.
By their numbers in this assay, from the lowest: compounds 3, 1, 2 and 4 (each within the scatter of the next, the first and the last beyond it).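

In this assay the step for iodo in place of tert-butyl on this aromatic carbon is a number 5 percentage points higher from compound 1 to compound 4 (within the scatter) and so shows that this position accepts a swap from 4 heavy atoms to 1 heavy atom with the two numbers still within the scatter of each other. Nothing at hand explains this result. The compounds shown leave open whether an amine or a carboxylic acid on this aromatic carbon would give a number beyond the scatter of compound 1. They also leave open how iodo reads out in the configuration drawn in compound 2.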